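The source may hold more compounds than are shown below. What is called first, only, known or untested is meant among the compounds shown, and "the series" means these compounds.

Compound 1 `N#CC1=C(N)N(c2ccc(S(N)(=O)=O)cc2)C2=C(CCCC2)C1c1ccccc1`: 10%
Compound 2 `N#CC1=C(N)N(c2ccc(S(N)(=O)=O)cc2)C2=C(CCCC2)C1c1ccc(O)cc1`: 42%
Compound 3 `N#CC1=C(N)N(c2ccc(S(N)(=O)=O)cc2)C2=C(CCCC2)C1c1ccc([N+](=O)[O-])cc1`: 5%

These three numbers come from a functional assay on Ehrlich cells (Mus musculus) for cytotoxicity, read by trypan blue exclusion, with a stated time of 2 h, tested at 25 ug/mL; a higher number here means a stronger effect of the compound at the concentration tested, a lower number a weaker effect. Compound 2 stands highest of the three, and both steps from it lie beyond the scatter: the step of a number 32 percentage points higher from compound 1 to compound 2 (beyond the scatter) adds the hydroxy, and the step of a number 37 percentage points lower from compound 2 to compound 3 (beyond the scatter) swaps it for nitro.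

Compound 4 `N#CC1=C(N)N(c2ccc(S(N)(=O)=O)cc2)C2=C(CCCC2)C1c1ccc(Cl)cc1Cl` has not yet been measured. Compared with compound 2 the change is 2,4-dichlorophenyl in place of 4-hydroxyphenyl on a saturated ring carbon. The two steps that bear on it are the reverse of a number 32 percentage points higher from compound 1 to compound 2 (beyond the scatter) and the step of a number 37 percentage points lower from compound 2 to compound 3 (beyond the scatter); both were large, and both removed the hydroxy from the aromatic ring. Compound 4 also loses that hydroxy, so a large drop is expected, a number 30 percentage points lower from compound 2 to compound 4 (beyond the scatter). Compound 4 is therefore estimated at 12%, within a range of 3% to 28%.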

Compound 4, a percentage reported as activity, at one concentration (the size of the read-out at that concentration, not a potency): 50%
Compound 4: the middle estimate sits 38 percentage points below what was measured, outside the stated range (above it).
By their numbers in this assay, from the lowest: compounds 3 and 1 (each within the scatter of the next); then compounds 2 and 4 (each within the scatter of the next).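

In this assay, the step of a number 8 percentage points higher from compound 2 to compound 4 (within the scatter) shows that the hydroxy is not required at this saturated ring carbon, since 2,4-dichlorophenyl, with no hydrogen-bond donor, stands level with 4-hydroxyphenyl. The steps of a number 40 percentage points higher from compound 1 to compound 4 (beyond the scatter) and a number 45 percentage points higher from compound 3 to compound 4 (beyond the scatter) show that a group without a hydroxy can also lift the read-out well clear of phenyl and 4-nitrophenyl. Nothing measured here explains why these groups give such different read-outs.

On these data alone, it remains open whether a single chlorine on the phenyl ring would be enough, and whether an amine or a methoxy group there would reach the same level.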